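The source may report more compounds than this note shows. Statements on the series, on what has been measured and on what is new or still open speak of the compounds shown alone.

- Compound 1 `CN(C)C(=O)c1cc2cnc(Nc3ccc(NC(=O)C4(C(=O)Nc5ccccc5F)CC4)cc3)nc2n1C1CCCC1`: 58%
- Compound 2 `CN(C)C(=O)c1cc2cnc(Nc3ccc(NC(=O)C4(C(=O)Nc5cccc(Cl)c5)CC4)cc3)nc2n1C1CCCC1`: 15.5%

In a functional assay on OVCAR-5 cells (Homo sapiens) for inhibition, read by CCK-8 assay, with a stated time of 72 h, tested at 1 uM (a higher number here means more inhibition of growth at the concentration tested, a lower number less inhibition of growth), compound 2, at 15.5%, holds the lower of the two numbers, and compound 1 stands at 58%. The unmeasured compound 3 `CN(C)C(=O)c1cc2cnc(Nc3ccc(NC(=O)C4(C(=O)Nc5ccc(Cl)c(C(F)(F)F)c5)CC4)cc3)nc2n1C1CCCC1` keeps the shared core and differs from compound 2 in one group: 4-chloro-3-(trifluoromethyl)phenyl in place of 3-chlorophenyl on an amide-type nitrogen. Here 4-chloro-3-(trifluoromethyl)phenyl stands in place of 3-chlorophenyl on an amide-type nitrogen.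

For the measured compounds named here, only one measured step bears on this change, made at the same place: a number 42.5 percentage points lower from compound 1 to compound 2 (beyond the scatter). It shows that the read-out can shift widely with the group here, but it involves a different pair of groups and gives no direction for this one. A smaller step is therefore expected, tilted slightly upward and perhaps within the scatter. The expected change is a number 4.5 percentage points higher from compound 2 to compound 3 (within the scatter). For compound 3 the estimated value is 20%, with an expected range of 5% to 45%.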

Compound 3, percent growth inhibition at one concentration: -2.4%
Compound 3: middle estimate off by 22.4 percentage points, on the high side; the whole stated range lies above it.
By their numbers in this assay, from the lowest: compound 3; then compound 2; then compound 1.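

In this assay, the step of a number 17.9 percentage points lower from compound 2 to compound 3 (beyond the scatter) shows that a chlorine-bearing phenyl on this amide-type nitrogen can still lose further growth inhibition, so the read-out was not yet at its floor with 3-chlorophenyl. With the step of a number 60.4 percentage points lower from compound 1 to compound 3 (beyond the scatter), the range at this position widens, and 2-fluorophenyl stands highest of the three groups, with both of its steps beyond the scatter. No measurement is available that explains why 4-chloro-3-(trifluoromethyl)phenyl gives the lowest number.

This change adds a trifluoromethyl group and also moves the chlorine, so the two contributions cannot be separated here. From the compounds shown here alone, it remains open how a plain phenyl, 3-(trifluoromethyl)phenyl, 2-chlorophenyl or a pyridine ring carrying an amine would read at this nitrogen.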